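The compounds below may be only part of what the source reports. "The series", "measured", "known", "first", "only" and "open" are said of these compounds alone.

Measured compounds:
- Compound 1 `O=c1[nH]cc(S(=O)(=O)Nc2cccc(-c3cn(-c4ccccc4)nn3)c2)c(=O)[nH]1`: 11200 nM
- Compound 2 `O=c1[nH]cc(S(=O)(=O)Nc2cccc(-c3cn(-c4ccccc4F)nn3)c2)c(=O)[nH]1`: 13900 nM

Both compounds were tested in a functional assay on HepG2 cells (Homo sapiens) for antiproliferative activity, read by MTT assay, with a stated time of 24 h; on this read-out lower numbers stand for stronger inhibition and higher numbers for weaker inhibition. Compound 1 gives 11200 nM, and compound 2 gives 13900 nM. Among the compounds with values here, compound 2 is one of only two measured compounds, and its number and that of compound 1 cannot be told apart, since the sole step measured so far, a 1.2-fold higher number from compound 1 to compound 2 (0.09 log units; within the scatter), stays within the scatter.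

Compound 3 `O=c1[nH]cc(S(=O)(=O)Nc2cccc(-c3cn(-c4cccc(F)c4)nn3)c2)c(=O)[nH]1` carries the change (3-fluorophenyl in place of 2-fluorophenyl on an aromatic nitrogen); it has the same atoms as compound 2, joined differently, on the shared core. Within the data shown here, the only measured step that bears on a fluorine at this phenyl ring is a 1.2-fold higher number from compound 1 to compound 2 (0.09 log units; within the scatter), and it was within the scatter. Moving that fluorine is therefore expected to give no step beyond the scatter in this assay, that is a 1.1-fold lower number from compound 2 to compound 3 (0.03 log units; within the scatter). Compound 3 is estimated at 13000 nM, with a likely range from 6000 nM to 28000 nM.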

Compound 3, half-maximal inhibitory concentration: > 20000 nM
Compound 3 was reported as a limit; the forecaster's own chance of this, stated with the estimate: 5%; middle value at least 1.5-fold (0.18 log units) away from the limit.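

In this assay compound 3 has no number of its own, only a limit: the limit of > 20000 nM in this assay, at which 1 of the 3 values shown sits. Swapping 2-fluorophenyl for 3-fluorophenyl gives an at least 1.4-fold higher number from compound 2 to compound 3 (0.15 log units; that floor lies within the scatter), and the comparison with the unsubstituted phenyl ring gives an at least 1.7-fold higher number from compound 1 to compound 3 (0.25 log units; that floor lies within the scatter). Both steps are only floors, so the true steps could be much larger or could remain within the scatter; the earlier pair gave no hint of this, and the limit now raises the possibility that where the fluorine sits on this ring matters, without proving it.

The compounds shown leave open how far the true value of compound 3 lies from the others, and so whether moving the fluorine has any real effect. They also leave open what an amine, a carboxylic acid or a methoxy group would do on this phenyl ring in place of the fluorine.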